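The compounds below may be only part of what the source reports. "The series", "measured", "known", "first", "only" and "open" are said of these compounds alone.

Of the compounds shown here, two have been measured so far in a functional assay on MKN-45 cells (Homo sapiens) for cytotoxicity, read by MTT assay, with a stated time of 72 h; a higher number here means a weaker inhibitor, a lower number a stronger inhibitor. Compound 1 `CN(C)CCn1cnnc1-c1cc(Oc2ccc(NC(=O)N/N=C/c3ccc(Cl)cc3Cl)cc2F)ccn1` gives 750 nM. Within the data shown here, compound 2 `CN(C)CCn1cnnc1-c1cc(Oc2ccc(NC(=O)N/N=C/c3ccc(F)cc3)cc2F)ccn1` gives 1030 nM, the highest of the two numbers, yet the only step to it, a 1.4-fold higher number from compound 1 to compound 2 (0.14 log units; within the scatter), stays within the scatter, so the two compounds cannot be ranked against each other on this assay.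

Compound 3 `COc1cc(/C=N/NC(=O)Nc2ccc(Oc3ccnc(-c4nncn4CCN(C)C)c3)c(F)c2)cc(OC)c1OC` is not yet measured. It differs from compound 2 in one place: 3,4,5-trimethoxyphenyl in place of 4-fluorophenyl on a carbon with a double bond to nitrogen. Among the measured compounds shown here, the only measured step that bears on this is the one from compound 1 to compound 2, which also exchanged one aromatic ring for another on the same carbon with a double bond to nitrogen, and that step, a 1.4-fold higher number from compound 1 to compound 2 (0.14 log units; within the scatter), was within the scatter. With a single precedent of this kind, and that one showing no movement beyond the scatter, the expectation for compound 3 is a step of about a 1.1-fold lower number from compound 2 to compound 3 (0.06 log units; within the scatter) in this assay, in no clear direction. Compound 3 is therefore estimated at 900 nM, within a range from 350 nM to 2500 nM.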

Compound 3, half-maximal inhibitory concentration: 2900 nM
The estimate for compound 3 lay 3.2-fold (0.51 log units) below the measured number, and the stated range ends below it.
By their numbers in this assay, from the lowest: compounds 1 and 2 (each within the scatter of the next); then compound 3.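

The earlier step left it possible that the ring on the carbon with a double bond to nitrogen could be exchanged freely in this assay, but this result shows otherwise: 3,4,5-trimethoxyphenyl in place of 4-fluorophenyl gives a 2.8-fold higher number from compound 2 to compound 3 (0.45 log units; beyond the scatter) and 3,4,5-trimethoxyphenyl in place of 2,4-dichlorophenyl gives a 3.9-fold higher number from compound 1 to compound 3 (0.59 log units; beyond the scatter) as a modest but real change. Both steps lie beyond the scatter and both point towards weaker inhibition, so the position tolerates the two halogen-bearing rings alike, while compound 3 is the weakest of the three. The entering group has 12 heavy atoms against 7 for 4-fluorophenyl and brings 3 hydrogen-bond acceptors where the rings it replaces have none, but no measurement here shows which of these differences, if either, lies behind the shift.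

These compounds cannot separate the number of methoxy groups from the presence of any methoxy group at all, and a phenyl ring carrying a single methoxy group would bear directly on that. As far as these compounds go, how this position responds to a ring bearing an amine or a carboxylic acid also remains open.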